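This account rests on a few compounds, and the source may have more. Where it says the series, first, only, none or still open, it means among the compounds named here.

Compound 1 `C[C@@H](Cn1ccc(-c2ccc(C#N)c(Cl)c2)n1)Nc1ccccc1` carries a phenyl on the amine nitrogen of the shared core. In an ADME assay on PC-3 cells (Homo sapiens) for cytotoxicity, read by CCK-8 assay, with a stated time of 6 days (a lower number here means a stronger inhibitor, a higher number a weaker inhibitor), compound 1 gives 3210 nM. Compound 2 `C[C@@H](Cn1ccc(-c2ccc(C#N)c(Cl)c2)n1)Nc1cccnc1` replaces that phenyl with a pyridin-3-yl; in this assay compound 2 gives only a limit, > 30000 nM, so its true number is not known. The step of an at least 9.3-fold higher number from compound 1 to compound 2 (0.97 log units; beyond the scatter) therefore shows a clear loss of potency, and the limit of > 30000 nM in this assay, at which 1 of the 3 values shown sits, records where that limit lies. Compound 3 `C[C@@H](Cn1ccc(-c2ccc(C#N)c(Cl)c2)n1)Nc1ccncc1` carries a pyridin-4-yl on the same nitrogen, but in this assay compound 3 gives "not determined" (no result reported), so its standing among the numbers is open. Compound 4 `Cc1ccnc(N[C@@H](C)Cn2ccc(-c3ccc(C#N)c(Cl)c3)n2)n1` differs from compound 3 by 4-methylpyrimidin-2-yl in place of pyridin-4-yl on an amine nitrogen. Going by the values given here, no measured step covers this exact change; the one step that exists, from a phenyl to a pyridin-3-yl, moved the number well beyond the scatter towards weaker inhibition. On that basis compound 4 is expected to be a weak inhibitor in this assay, estimated at 20000 nM, within roughly 5000 nM to 40000 nM.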

Compound 4, half-maximal inhibitory concentration: > 30000 nM
Compound 4: no number, only a limit; the forecaster's own chance of this, stated with the estimate: 50%; middle value at least 1.5-fold (0.17 log units) from the limit.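

In this assay, a second group in place of the phenyl on the amine nitrogen, this time the 4-methylpyrimidin-2-yl, also goes with weaker inhibition: the change is an at least 9.3-fold higher number from compound 1 to compound 4 (0.97 log units; beyond the scatter). The loss seen with pyridin-3-yl is therefore not confined to that one group, as both aromatic rings with hetero atoms among the measured compounds lie well away from the phenyl of compound 1. Compound 2 and compound 4 both stop at the same limit, not at true numbers, so the step between them cannot be read and the two groups cannot be ranked: the limit of > 30000 nM in this assay, at which 2 of the 4 values shown sit.

Going by these compounds, with no result for compound 3, the place of pyridin-4-yl remains open. Also open, on these data alone, is how a methoxyphenyl or a simple ethyl group on this nitrogen would compare with the phenyl of compound 1.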